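Swapping a para chloro for trifluoromethoxy on a hydrazone aryl

The source may hold more compounds than are shown below. What is called first, only, known or untested is meant among the compounds shown, and "the series" means these compounds.

The measured compounds, with their numbers in a functional assay on PC-3 cells (Homo sapiens) for antiproliferative activity, read by MTT assay; a higher number here means a weaker inhibitor, a lower number a stronger inhibitor:
- compound 1, `Cn1c(=O)c(=O)n(C2CCCC2)c2nc(N/N=C/c3ccc(Cl)cc3)ncc21`: 8420 nM
- compound 2, `Cc1ccc(/C=N/Nc2ncc3c(n2)n(C2CCCC2)c(=O)c(=O)n3C)cc1C`: 39000 nM
- compound 3, `Cn1c(=O)c(=O)n(C2CCCC2)c2nc(N/N=C/c3ccccc3Cl)ncc21`: 16300 nM

Compound 1 gives the lowest number of the three in this assay. Its nearest neighbour is compound 3, at a 1.9-fold higher number from compound 1 to compound 3 (0.29 log units; within the scatter), a difference that stays within the scatter, and the furthest is compound 2, at a 4.6-fold higher number from compound 1 to compound 2 (0.67 log units; beyond the scatter). The unmeasured compound 4, `Cn1c(=O)c(=O)n(C2CCCC2)c2nc(N/N=C/c3ccc(OC(F)(F)F)cc3)ncc21`, differs from compound 1 in one place: trifluoromethoxy in place of chloro on an aromatic carbon, para to a large group. Both measured steps that change this aryl ring move the number upward or leave it unchanged within the scatter; neither produced a lower number. Within the data shown here, the only change that kept a substituent in the same position, from compound 1 to compound 3, stayed within the scatter. A small step upward or none beyond the scatter is therefore expected for compound 4, namely a 1.4-fold higher number from compound 1 to compound 4 (0.15 log units; within the scatter). Compound 4 is estimated at 12000 nM in this assay, with a range from 5000 nM to 35000 nM.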

Compound 4, half-maximal inhibitory concentration: 7180 nM
The estimate for compound 4 lay 1.7-fold (0.22 log units) above the measured number, within the range that was stated.
By their numbers in this assay, from the lowest: compounds 4, 1 and 3 (each within the scatter of the next, the first and the last beyond it); then compound 2.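

In this assay, trifluoromethoxy in place of chloro gives a 1.2-fold lower number from compound 1 to compound 4 (0.07 log units; within the scatter), so at this position five heavy atoms and a hydrogen-bond acceptor can replace a single chlorine atom without a change beyond the scatter. The earlier compounds shown here showed what happened when the aryl substituents were exchanged or the chloro stood elsewhere on the ring, but not whether a substantially larger group could occupy this same position with so little effect on the number. Nothing measured here explains why the two groups read alike.

Still open, as far as these compounds go, is how an amine, a carboxylic acid or a longer alkoxy chain would behave at this position. Also open, from the compounds shown here alone, is whether any group here can bring the number down beyond the scatter from compound 1.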